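Series notes: replacing 3,4-dichlorophenyl with 3-nitrophenyl

A few compounds are considered here, and "the series" means these few. Any claim that something is new, unique, unknown or untested is made for them only; others in the source may bear on it.

compound 1 `COc1cc(/C=C2\CN(C)C/C(=C\c3ccc(Br)cc3)C2=O)cc(OC)c1` gives 4270 nM
compound 2 `COc1cc(/C=C2\CN(C)C/C(=C\c3ccc(Cl)c(Cl)c3)C2=O)cc(OC)c1` gives 3260 nM

Both values come from a functional assay on THP-1 cells (Homo sapiens) for cytotoxicity, read by MTT assay, with a stated time of 24 h; a lower number here means a stronger inhibitor, a higher number a weaker inhibitor. Among the compounds with values here, compound 2 stands within the scatter of compound 1, the only other compound measured. Compound 3 `COc1cc(/C=C2\CN(C)C/C(=C\c3cccc([N+](=O)[O-])c3)C2=O)cc(OC)c1` carries 3-nitrophenyl in place of 3,4-dichlorophenyl on a double-bonded chain carbon bound to a double-bonded ring carbon. Within the data shown here, the one measured step at this place, a 1.3-fold lower number from compound 1 to compound 2 (0.12 log units; within the scatter), stayed within the scatter, but it involved no 3-nitrophenyl group and so offers limited guidance. No step beyond the scatter is therefore expected in this assay, and no direction is favoured. The estimated step is a 1.1-fold higher number from compound 2 to compound 3 (0.03 log units; within the scatter). For compound 3 the expected value is 3500 nM, with an estimated range of 1500 nM to 8000 nM.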

Compound 3, half-maximal inhibitory concentration: 1770 nM
Beside the measured number, compound 3's estimate is 2.0-fold (0.30 log units) above it; low and high end bracket the measured number.
By their numbers in this assay, from the lowest: compounds 3, 2 and 1 (each within the scatter of the next, the first and the last beyond it).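

In this assay, this place on a double-bonded chain carbon bound to a double-bonded ring carbon now shows its first step beyond the scatter, though a modest one: 3-nitrophenyl in place of 4-bromophenyl gives a 2.4-fold lower number from compound 1 to compound 3 (0.38 log units; beyond the scatter). Set against 3,4-dichlorophenyl, the same group gives a 1.8-fold lower number from compound 2 to compound 3 (0.27 log units; within the scatter), so only the two ends of the series separate. Nothing shown accounts for this result.

On these data alone, how an aminophenyl or a carboxyphenyl group would read at this place remains open. Also open, as far as these compounds go, is whether the 3-nitrophenyl result holds with other changes on the shared core.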